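Same Atoms, Joined Differently: Compound 3 Beside Compound 1

The compounds below may be only part of what the source reports. "The series", "measured", "known", "first", "only" and "open" are said of these compounds alone.

Compound 1 `Cc1cc(=O)n(-c2ccc(F)c(F)c2)nc1C(=O)Nc1ccc(Oc2ncnc3ccsc23)cc1` was examined in a functional assay on HepG2 cells (Homo sapiens) for cytotoxicity, read by MTT assay, with a stated time of 72 h (a lower number here means a stronger inhibitor, a higher number a weaker inhibitor), where compound 1 gives 9230 nM, the lowest of the two numbers recorded. Its companion compound 2 `Cc1ccc(-n2nc(C(=O)Nc3ccc(Oc4ncnc5ccsc45)cc3)c(C)cc2=O)c(C)c1` gives 17900 nM in this assay; the step of a 1.9-fold higher number from compound 1 to compound 2 (0.29 log units; within the scatter) separates them and falls within the scatter. The unmeasured compound 3 `Cc1cc(=O)n(-c2ccc(F)c(F)c2)nc1C(=O)Nc1ccc(Oc2ncnc3sccc23)cc1` keeps the 3,4-difluorophenyl of compound 1 and differs only on an oxygen on an aromatic ring: a group of 9 heavy atoms (6 carbon, 2 nitrogen, 1 sulfur; one five-membered aromatic ring with 1 hetero atom, one six-membered aromatic ring with 2 hetero atoms) in place of a group of 9 heavy atoms (6 carbon, 2 nitrogen, 1 sulfur; one five-membered aromatic ring with 1 hetero atom, one six-membered aromatic ring with 2 hetero atoms), on an oxygen on an aromatic ring; the two have the same atoms, joined differently. Among the compounds with values here, no measured step touches this part of the molecule, since the single recorded step from compound 1 to compound 2 alters the group on an aromatic nitrogen instead. With nothing pointing either way, this change is expected to produce no step beyond the scatter in this assay. Compound 3 is therefore estimated at 10000 nM, within a range from 4000 nM to 25000 nM. The step expected from this estimate is a 1.1-fold higher number from compound 1 to compound 3 (0.03 log units; within the scatter).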

Compound 3, half-maximal inhibitory concentration: 16800 nM
Estimate against measurement, compound 3: 1.7-fold (0.23 log units) below, and the stated range covers the measured number.
By their numbers in this assay, from the lowest: compounds 1, 3 and 2 (each within the scatter of the next).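

Within the data shown here, the earlier pair varied only the group on an aromatic nitrogen, so this result gives the first reading at the oxygen on an aromatic ring. In this assay, the step is a 1.8-fold higher number from compound 1 to compound 3 (0.26 log units; within the scatter), so with the 3,4-difluorophenyl kept, joining the same atoms differently at this place gives no difference that can be told from the scatter. Nothing available speaks to why the two groups read alike here.

On these data alone, it remains open whether a quite different group on that oxygen, such as a plain phenyl or a pyridine, would also stay within the scatter of compound 1 in this assay. As far as these compounds go, it is also open whether the same rearranged group would read alike when paired with the 2,4-dimethylphenyl of compound 2.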